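Replacing bromo with methyl in compound 3

The source may report more compounds than this note shows. Statements on the series, on what has been measured and on what is new or still open speak of the compounds shown alone.

Compound 1 `C=C(Br)C(=O)Nc1ccc(/C=C/C(=O)c2ccc(C)cc2)cc1`: 2100 nM
Compound 2 `Nc1ccc(/C=C/C(=O)c2ccc(F)cc2)cc1`: 40000 nM
Compound 3 `Nc1ccc(/C=C/C(=O)c2ccc(Br)cc2)cc1`: 49000 nM

In a functional assay on HeLa cells (Homo sapiens) for antiproliferative activity, with a stated time of 48 h (on this read-out lower numbers stand for stronger inhibition and higher numbers for weaker inhibition), compound 3 gives 49000 nM, which lies within the scatter of compound 2 and well above the number of compound 1. Compound 4 `Cc1ccc(C(=O)/C=C/c2ccc(N)cc2)cc1` differs from compound 3 by methyl in place of bromo on an aromatic carbon, with methyl in place of bromo on an aromatic carbon, para to a large group. Among the compounds with values here, the one measured step at this place is a 1.2-fold higher number from compound 2 to compound 3 (0.09 log units; within the scatter), and it stays within the scatter. No step beyond the scatter is therefore expected here. The expected change is a 1.2-fold lower number from compound 3 to compound 4 (0.09 log units; within the scatter). Compound 4 is estimated at 40000 nM, with an expected range of 18000 nM to 80000 nM.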

Compound 4, half-maximal inhibitory concentration: 40000 nM
Compound 4: the middle estimate sits on the measured number at the digits printed; low and high end bracket the measured number.
By their numbers in this assay, from the lowest: compound 1; then compounds 2, 4 and 3 (each within the scatter of the next).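

In this assay the aromatic carbon para to a large group now carries fluoro, bromo or methyl, and both a 1.2-fold lower number from compound 3 to compound 4 (0.09 log units; within the scatter) and no change at the digits printed from compound 2 to compound 4 (within the scatter) stay within the scatter, so a carbon group reads here like either halogen. With methyl held fixed, hydrogen in place of (1-bromoethenyl)carbonyl on the nitrogen gives a 19-fold higher number from compound 1 to compound 4 (1.28 log units; beyond the scatter) and lies beyond the scatter, unlike any change shown at the aromatic carbon. Nothing measured here offers a reason for either result.

From the compounds shown here alone, whether an amine or a carboxylic acid on that aromatic carbon would also stay within the scatter remains open. So does whether the (1-bromoethenyl)carbonyl group gives a step of similar size with fluoro or bromo in place of methyl.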